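This account rests on a few compounds, and the source may have more. Where it says the series, first, only, none or still open, it means among the compounds named here.

Compound 1 `COc1ccccc1N1CCN(CCCNc2nc(C)cc(C)c2C(N)=O)CC1` gives 10 nM in a functional assay for antagonist activity at Alpha-1A adrenergic receptor (Oryctolagus cuniculus); on this read-out lower numbers stand for tighter binding and higher numbers for weaker binding.
Compound 2 `CCOc1ccccc1N1CCN(CCCNc2ncccc2C(=O)N(C)C)CC1` gives 0.501 nM.
Compound 3 `Cc1cnccc1N1CCN(CCCNc2ncccc2C(=O)N(C)C)CC1` gives 200 nM.

Compound 2 gives the lowest number of the three; compound 1 and compound 3 both lie higher, beyond the scatter. Compound 4 `CN(C)C(=O)c1cccnc1NCCCN1CCN(c2ccccc2Cc2ccccc2)CC1` differs from compound 2 by benzyl in place of ethoxy on an aromatic carbon. Within the data shown here, the one single-point step measured, a 400-fold higher number from compound 2 to compound 3 (2.60 log units; beyond the scatter), exchanges the whole aryl on the ring amine nitrogen and shows that this part of the series is sensitive, but it does not test an ethoxy-to-benzyl swap. Compound 1 and compound 2 differ in several places, so their gap says nothing specific about the ethoxy. Expectation: a moderate rise, a 6.0-fold higher number from compound 2 to compound 4 (0.78 log units; beyond the scatter), with wide uncertainty. For compound 4 the estimate is 3 nM, range 0.5 nM to 20 nM.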

Compound 4, dissociation constant: 6.31 nM
The estimate for compound 4 lay 2.1-fold (0.32 log units) below the measured number; the measured number falls inside the stated range.
By their numbers in this assay, from the lowest: compound 2; then compounds 4 and 1 (each within the scatter of the next); then compound 3.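

Read in this assay, the step of a 13-fold higher number from compound 2 to compound 4 (1.10 log units; beyond the scatter) changes only the substituent and keeps the aryl ring on the ring amine nitrogen, so this position ortho to a large group is sensitive by itself, which the whole-aryl exchange could not show. Benzyl does not abolish the read-out: compound 4 gives 6.31 nM in this assay. No available evidence bears on this rise.

Going by these compounds, whether the rise follows the lost oxygen or the added ring remains open. A phenoxy group or a longer alkoxy chain at this position on the core of compound 2 would separate the two.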